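Adding Bromine to the Ring on the Nitrogen of Compound 1

The source may hold more compounds than are shown below. What is called first, only, known or untested is meant among the compounds shown, and "the series" means these compounds.

Compound 1 `COc1cc2ncnc(Nc3ccccc3F)c2c(OC)c1OC` gives 0.9% in a functional assay on PC-3 cells (Homo sapiens) for inhibition, read by MTT assay, with a stated time of 72 h, tested at 1 uM; on this read-out lower numbers stand for less inhibition of growth and higher numbers for more inhibition of growth at the one concentration tested.
Compound 2 `COc1cc2ncnc(Nc3cc(C(F)(F)F)ccc3F)c2c(OC)c1OC` gives 7.6%.
Compound 3 `COc1cc2ncnc(Nc3ccccc3[N+](=O)[O-])c2c(OC)c1OC` gives 11.3%.

Compound 1 has the lowest of these three numbers. Compound 2 stands nearest to it, with a number 6.7 percentage points higher from compound 1 to compound 2 (within the scatter), a step that puts trifluoromethyl in place of hydrogen on an aromatic carbon. Compound 3 stands furthest, with a number 10.4 percentage points higher from compound 1 to compound 3 (beyond the scatter), a step that puts nitro in place of fluoro on an aromatic carbon. The unmeasured compound 4 `COc1cc2ncnc(Nc3cc(F)ccc3Br)c2c(OC)c1OC` differs from compound 1 as follows: 2-bromo-5-fluorophenyl in place of 2-fluorophenyl on a nitrogen on an aromatic ring. The entering group carries both a bromine and a fluorine, whereas the leaving group carries a fluorine only.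

Among the compounds with values here, no measured step matches this change exactly. Both measured steps alter the ring on the nitrogen and both raise the number, one within the scatter and one modestly beyond it. A step of that same small upward kind is therefore expected, a number 7.1 percentage points higher from compound 1 to compound 4 (within the scatter). Compound 4 is estimated at 8%, with a range from 0% to 20%.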

Compound 4, percent growth inhibition at one concentration: 12.8%
Compound 4: middle estimate off by 4.8 percentage points, on the low side; low and high end bracket the measured number.
By their numbers in this assay, from the lowest: compounds 1, 2, 3 and 4 (each within the scatter of the next, the first and the last beyond it).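

In this assay, replacing 2-fluorophenyl with 2-bromo-5-fluorophenyl on the nitrogen gives a number 11.9 percentage points higher from compound 1 to compound 4 (beyond the scatter). This is the second change to this ring to move the number beyond the scatter, after the nitro step, while the trifluoromethyl step in compound 2 stays within it. Within the data shown here, the ring on the nitrogen therefore accepts a bromine alongside a fluorine with a modest gain in growth inhibition, though the single step cannot separate what the bromine adds from what the altered fluorine placement adds. Nothing shown here explains why the number rises.

A simple 2-bromophenyl group would help to separate those two parts. As far as these compounds go, it also remains open how an amine or a carboxylic acid on this ring would affect the number.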